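This account rests on a few compounds, and the source may have more. Where it says the series, first, only, none or still open, it means among the compounds named here.

Measured compounds:
- compound 1, `O=C(NCCCCc1ccccc1)n1c(=O)oc2ccc(Br)cc21`: 22 nM
- compound 2, `O=C(NCCSCc1ccccc1)n1c(=O)oc2ccccc21`: 65 nM
- compound 3, `Cc1ccc2c(c1)oc(=O)n2C(=O)NCCCCc1ccccc1`: 66 nM

The read-out throughout is an assay on HEK293 cells for inhibition of acid ceramidase (Homo sapiens), with a stated time of 10 min; on this read-out higher numbers stand for weaker inhibition and lower numbers for stronger inhibition. Among the three measured compounds, compound 3 gives the highest number, at 66 nM. Its nearest neighbour is compound 2, whose value of 65 nM lies within the scatter of repeated measurements, so no order between compound 2 and compound 3 can be read from these two numbers. Compound 1, at 22 nM, sits furthest from compound 3, and that gap is beyond the scatter; the two structures differ in more than one place, so nothing further is drawn from the pair.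

The compound now in question is compound 4, `O=C(NCCCCc1ccccc1)n1c(=O)oc2cc(F)ccc21`. Relative to compound 3 the change is fluoro in place of methyl on an aromatic carbon. No step of this kind has yet been measured in this series, so the expectation rests only on the numbers shown. Compound 1, which carries a halogen on its core and gives 22 nM, is the sole hint that a halogen on the core is compatible with a lower number. On that basis compound 4 is expected to give 45 nM, within a range of 15 nM to 130 nM. The step this estimate implies is a 1.5-fold lower number from compound 3 to compound 4 (0.17 log units; within the scatter), expected to be small and at the edge of the scatter, if beyond it at all.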

Compound 4, half-maximal inhibitory concentration: 31 nM
Beside the measured number, compound 4's estimate is 1.5-fold (0.16 log units) above it; low and high end bracket the measured number.
By their numbers in this assay, from the lowest: compounds 1 and 4 (each within the scatter of the next); then compounds 2 and 3 (each within the scatter of the next).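

In this assay, among the compounds shown here, putting fluoro in place of methyl on the aromatic carbon gives a 2.1-fold lower number from compound 3 to compound 4 (0.33 log units; beyond the scatter), and this is the first step in the set that ties a change in the number to a single place on the molecule. The earlier compounds shown here differ from one another in more than one place, so they could not show that this carbon, meta to a fused ring and para to a fused ring, responds to what it carries while the chain and the rest of the core stay the same. For the compounds shown here, the step shows only that the number moves with this exchange, and nothing available bears on what lies behind it.

From the compounds shown here alone, it remains open whether the lower number goes with the arrival of fluoro or with the departure of methyl, a question that a plain hydrogen at this carbon, with the same chain, would help to settle. Going by these compounds, it is equally open how other groups at this carbon, such as chloro, methoxy or trifluoromethyl, would compare with fluoro and methyl, and whether fluoro would give a similar step on another carbon of the same ring.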